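Changing the group on the carbonyl of compound 2

The source may hold more compounds than are shown below. What is called first, only, known or untested is meant among the compounds shown, and "the series" means these compounds.

Measured in a functional assay on HCT-116 cells (Homo sapiens) for inhibition, with a stated time of 72 h; on this read-out higher numbers stand for weaker inhibition and lower numbers for stronger inhibition:
Compound 1 `O=C(/C=C/c1ccc(-c2ccccc2)cc1)NO` gives 1600 nM
Compound 2 `NNC(=O)/C=C/c1ccc(-c2ccccc2)cc1` gives 11900 nM

Going by the values given here, of the two numbers so far, compound 2 with 11900 nM is the higher one, and compound 1 is its only neighbour. Compound 3 `CC(=O)SCC(=O)/C=C/c1ccc(-c2ccccc2)cc1` has not yet been measured. Its structure departs from compound 2 as follows: (acetylsulfanyl)methyl in place of aminoamino on a carbonyl carbon with (acetylsulfanyl)methyl in place of aminoamino on a carbonyl carbon. Among the compounds with values here, no measured compound carries the entering group. Within the data shown here, the only measured step bearing on this change is a 7.4-fold higher number from compound 1 to compound 2 (0.87 log units; beyond the scatter) and it was modest, with amino in place of hydroxy on an amide-type nitrogen. It offers a size, not a direction. A modest move to a lower number is tentatively expected, and the expected step is a 2.4-fold lower number from compound 2 to compound 3 (0.38 log units; beyond the scatter) with wide uncertainty. The estimated value for compound 3 is 5000 nM within an expected range of 1500 nM to 20000 nM in this assay for now.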

Compound 3, half-maximal inhibitory concentration: 14000 nM
Beside the measured number, compound 3's estimate is 2.8-fold (0.45 log units) below it; the range from low to high includes it.
By their numbers in this assay, from the lowest: compound 1; then compounds 2 and 3 (each within the scatter of the next).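

In this assay, replacing aminoamino with (acetylsulfanyl)methyl on the carbonyl carbon gives no readable change: the result is a 1.2-fold higher number from compound 2 to compound 3 (0.07 log units; within the scatter). Compared with hydroxyamino at the same place, the new group gives an 8.8-fold higher number from compound 1 to compound 3 (0.94 log units; beyond the scatter), so compound 1 remains the strongest inhibitor of the three, and two quite different replacements for its hydroxyamino group, in compound 2 and compound 3, end up within the scatter of each other. No supporting data are available to explain this result.

The compounds shown leave open whether a sulfanylmethyl group without the acetyl, a carboxylic acid or a simple amine on this carbonyl carbon would stay level with compound 2 and compound 3 or approach compound 1. Going by these compounds alone, they also leave open whether hydroxyamino is the only group here that separates from the others.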